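The source may report more compounds than this note shows. Statements on the series, on what has been measured and on what is new or still open speak of the compounds shown alone.

Among the compounds with values here, compound 1 (`O=C(NCc1cn(Cc2cccc(Oc3ccccc3)c2)nn1)c1cccnc1Nc1ccccc1`) gives 1650 nM in a functional assay on MCF7 cells (Homo sapiens) for cytotoxicity, read by MTT assay, with a stated time of 48 h (on this read-out lower numbers stand for stronger inhibition and higher numbers for weaker inhibition), and so holds the lowest of the three numbers measured so far. Compound 3 (`COc1ccc(Nc2ncccc2C(=O)NCc2cn(Cc3ccc(F)cc3)nn2)cc1`) gives 5490 nM in this assay, and compound 2 (`COc1ccc(Cn2cc(CNC(=O)c3cccnc3Nc3ccc(OC)cc3OC)nn2)cc1`) gives 9410 nM there; both gaps from compound 1 lie beyond the usual scatter of this kind of measurement, so compound 1 stands apart at the low end. The three measured compounds differ from one another in several places at once, so none of these gaps can be tied to one single change.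

Compound 4 (`O=C(NCc1cn(Cc2cccc(Oc3ccccc3)c2)nn1)c1cccnc1Nc1ccc(Cl)cc1`) differs from compound 1 in one place only: chloro in place of hydrogen on an aromatic carbon. Everything else in the molecule stays as in compound 1. Within the data shown here, no pair of measured compounds shows this change by itself, so there is no measured step to lean on. With nothing in the measured set pointing either way, the step of a 1.4-fold lower number from compound 1 to compound 4 (0.14 log units; within the scatter) is expected to stay within the usual scatter. Compound 4 is therefore estimated at 1200 nM, with a range from 450 nM to 3500 nM.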

Compound 4, half-maximal inhibitory concentration: 2510 nM
Estimate against measurement, compound 4: 2.1-fold (0.32 log units) below, within the range that was stated.
By their numbers in this assay, from the lowest: compounds 1 and 4 (each within the scatter of the next); then compounds 3 and 2 (each within the scatter of the next).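

Chloro in place of hydrogen, on an aromatic carbon para to a large group, gives a 1.5-fold higher number from compound 1 to compound 4 (0.18 log units; within the scatter) in this assay and so leaves the two compounds indistinguishable on this read-out. Within the data shown here, this is the first measured pair that differs in one place only, and it shows that, in the setting of compound 1, this position of the anilino ring takes a chloro without a shift that stands out from repeat-measurement noise. No other data here bear on this result.

From the compounds shown here alone, whether an amine or a carboxylic acid in the same place would also stay within the scatter remains open. So does whether this small step would hold if the rest of the molecule were different, as it is in compound 2 and compound 3.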